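Two Chlorines Change Places: From Compound 1 to Compound 4

The source may report more compounds than this note shows. Statements on the series, on what has been measured and on what is new or still open speak of the compounds shown alone.

Compound 1 `COC(=O)C1=C(C)N=C(C)/C(=C(\O)OC)C1c1cc(Cl)cc(Cl)c1` gives 93.3 nM in a functional assay (muscle tissue) with Cavia porcellus as the target; on this read-out higher numbers stand for an effect only at larger amounts of compound and lower numbers for an effect already at smaller amounts.
Compound 2 `COC(=O)C1=C(C)N=C(C)/C(=C(\O)OC)C1c1ccc(F)cc1` gives 129 nM in this assay.
Compound 3 `COC(=O)C1=C(C)N=C(C)/C(=C(\O)OC)C1c1ccc(Br)cc1` gives 540 nM in this assay.

Compound 1 sits at the low end of these three numbers, but the gap to compound 2, a 1.4-fold higher number from compound 1 to compound 2 (0.14 log units; within the scatter), is within the scatter, so the two cannot be told apart on this evidence. Only the gap to compound 3, a 5.8-fold higher number from compound 1 to compound 3 (0.76 log units; beyond the scatter), is beyond it, and between the two single-halogen compounds there is a 4.2-fold higher number from compound 2 to compound 3 (0.62 log units; beyond the scatter).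

Compound 4 `COC(=O)C1=C(C)N=C(C)/C(=C(\O)OC)C1c1ccc(Cl)cc1Cl` keeps every atom of compound 1 and differs only in how the two chlorines are placed: 2,4-dichlorophenyl in place of 3,5-dichlorophenyl on a saturated ring carbon.

Going by the values given here, no measured step moves a chlorine from one aromatic position to another, so nothing here tells directly how this swap will play out in this assay. What the three measured compounds show is that changing the halogen pattern on this aryl ring shifts the number by at most a modest amount, as in a 5.8-fold higher number from compound 1 to compound 3 (0.76 log units; beyond the scatter), and sometimes by nothing beyond the scatter, as in a 1.4-fold higher number from compound 1 to compound 2 (0.14 log units; within the scatter). The expectation for compound 4 is therefore a step of a 1.6-fold higher number from compound 1 to compound 4 (0.21 log units; within the scatter), likely within or just beyond the scatter, with a wide range in both directions. Compound 4 is estimated at 150 nM, between 45 nM and 500 nM.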

Compound 4, half-maximal effective concentration: 640 nM
For compound 4 the middle estimate is 4.3-fold (0.63 log units) below the measured one; measured number outside the range, above it.
By their numbers in this assay, from the lowest: compounds 1 and 2 (each within the scatter of the next); then compounds 3 and 4 (each within the scatter of the next).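

Moving the same two chlorines around the ring, with no atom gained or lost, gives a 6.9-fold higher number from compound 1 to compound 4 (0.84 log units; beyond the scatter) in this assay, so at this saturated ring carbon the arrangement of the halogens on the aryl group matters, and not only which halogens are present. The step of a 5.0-fold higher number from compound 2 to compound 4 (0.70 log units; beyond the scatter) is also beyond the scatter, while the step of a 1.2-fold higher number from compound 3 to compound 4 (0.07 log units; within the scatter) is within it, so the 2,4-dichlorophenyl and 4-bromophenyl compounds cannot be told apart on this read-out even though their halogens differ in kind and number. Nothing measured here explains why the arrangement of the chlorines has an effect of this size.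

As far as these compounds go, it remains open whether the change from 3,5-dichlorophenyl to 2,4-dichlorophenyl depends on one chlorine or on both, a question that a ring bearing a single chlorine, such as 4-chlorophenyl or 2-chlorophenyl, could help to answer. Also open is where a plain phenyl group, or a ring carrying a non-halogen group such as 4-methoxyphenyl, would fall among these numbers.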